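Chloro on the pendant phenyl of compound 2

The compounds below may be only part of what the source reports. "The series", "measured", "known", "first", "only" and "open" are said of these compounds alone.

Compound 2 `O=C(Nc1ccc(Oc2ccnc3[nH]ccc23)c(F)c1)c1ccc(-c2ccccc2)cn1` is the reference for this step. Among the measured compounds shown here, in a functional assay on PC-3 cells (Homo sapiens) for cytotoxicity, read by MTT assay, with a stated time of 72 h (a lower number here means a stronger inhibitor, a higher number a weaker inhibitor), compound 2 gives 760 nM, the only numerical value so far. Compound 1 `CCc1ccc(-c2ccc(C(=O)Nc3ccc(Oc4ccnc5[nH]ccc45)cc3)nc2)cc1` gives > 10000 nM in this assay, which is a limit of the assay rather than a number, namely (the limit of > 10000 nM in this assay, at which 1 of the 2 values shown sits). For the measured compounds named here, compound 1 and compound 2 differ in more than one place, so their two values can only be set side by side, with no step drawn between them. Compound 3 `O=C(Nc1ccc(Oc2ccnc3[nH]ccc23)c(F)c1)c1ccc(-c2ccc(Cl)cc2)cn1` is the untested member. From compound 2 to compound 3 the change is chloro in place of hydrogen on an aromatic carbon, para to a large group. Going by the values given here, no measured step speaks to this change. A modest gain, near the edge of the scatter, is expected: a 1.5-fold lower number from compound 2 to compound 3 (0.18 log units; within the scatter). Compound 3 is estimated at 500 nM in this assay, with a likely range from 150 nM to 2000 nM.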

Compound 3, half-maximal inhibitory concentration: 3030 nM
Beside the measured number, compound 3's estimate is 6.1-fold (0.78 log units) below it, and the stated range ends below it.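

In this assay, among the compounds shown here, phenyl to 4-chlorophenyl on compound 2 gives the only step that can be read (a 4.0-fold higher number from compound 2 to compound 3 (0.60 log units; beyond the scatter)). For the compounds shown here, the earlier pair differed in more than one place, so this is the first sign of how the pendant ring responds to a change at this carbon. One chlorine atom in place of hydrogen moves the number beyond the scatter, and the direction is toward a weaker inhibitor. No measurement shown gives a reason for this loss.

Going by these compounds, whether the loss belongs to chloro alone or to any group at this carbon stays open, and a fluoro, a methoxy or an amine there would separate the two readings. The value of compound 1 is a limit of the assay (> 10000 nM) and, with more than one place changed from compound 2, does not settle the question.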